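This account rests on a few compounds, and the source may have more. Where it says the series, first, only, none or still open, it means among the compounds named here.

Working notes on the series. The shared core is that of compound 1 `CC1(C)C=C(n2ccccc2=O)c2ccccc2O1`, which in a functional assay (trachea) with Rattus norvegicus as the target (on this read-out higher numbers stand for higher potency (the scale is a negative logarithm) and lower numbers for lower potency), gives 5.05. Compound 2 `CC(=O)c1ccc2c(c1)C(n1ccccc1=O)=CC(C)(C)O2` carries an acetyl on an aromatic carbon and in this assay gives 6.65; compound 3 `CC1(C)C=C(n2ccccc2=O)c2cc(C(=O)c3ccccc3F)ccc2O1` carries a (2-fluorophenyl)carbonyl at the same place and gives 6.34. Compound 3 thus stands second of the three numbers: the step of a number 0.31 log units lower from compound 2 to compound 3 (beyond the scatter) separates it from compound 2, and the step of a number 1.29 log units higher from compound 1 to compound 3 (beyond the scatter) from compound 1.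

Compound 4 `CC1(C)C=C(n2ccccc2=O)c2cc(C=C(C#N)C#N)ccc2O1` is the next member. The change from compound 3 is 2,2-dicyanoethenyl in place of (2-fluorophenyl)carbonyl on an aromatic carbon. Within the data shown here, no measured pair covers a 2,2-dicyanoethenyl. Among the measured compounds shown here, the steps that bear on it are the two substitutions of hydrogen at this aromatic carbon, a number 1.60 log units higher from compound 1 to compound 2 (beyond the scatter) and a number 1.29 log units higher from compound 1 to compound 3 (beyond the scatter), both large and in the same direction, and the exchange of one carbonyl substituent for another, a number 0.31 log units lower from compound 2 to compound 3 (beyond the scatter), which was modest. Together they suggest that the position tolerates different groups with a common gain over compound 1, so for compound 4 a step of about a number 0.04 log units lower from compound 3 to compound 4 (within the scatter) is expected, that is none clearly beyond the scatter. Compound 4 is therefore estimated at 6.3 in this assay, within a range from 5.5 to 7.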

Compound 4, logarithm of the reciprocal of the active concentration, log(1/C): 6.3
Compound 4: middle estimate and measured number agree at the digits printed; low and high end bracket the measured number.
By their numbers in this assay, from the lowest: compound 1; then compounds 4 and 3 (each within the scatter of the next); then compound 2.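

The step of a number 1.25 log units higher from compound 1 to compound 4 (beyond the scatter) shows that in this assay the large gain at this aromatic carbon is not confined to the carbonyl groups of compound 2 and compound 3, since 2,2-dicyanoethenyl holds no carbonyl and no ring. Replacing (2-fluorophenyl)carbonyl with this group changes the heavy-atom count from 9 to 6 and swaps the fluorinated aromatic ring for a double bond and two nitriles, yet the step of a number 0.04 log units lower from compound 3 to compound 4 (within the scatter) gives no readable difference. Acetyl still keeps a modest edge, as the step of a number 0.35 log units lower from compound 2 to compound 4 (beyond the scatter) shows, so compound 2 remains the highest of the four, and no measurement is available that would account for these numbers.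

The compounds shown leave open whether an amine, a carboxylic acid or a simple nitrile at this aromatic carbon would keep the gain over compound 1. They also leave open whether a longer chain carrying the two nitriles would stay level with compound 3 and compound 4 or fall back towards compound 1.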